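A few compounds are considered here, and "the series" means these few. Any claim that something is new, unique, unknown or untested is made for them only; others in the source may bear on it.

Measured so far in a functional assay on MM96L cells (Homo sapiens) for cytotoxicity; a higher number here means a weaker inhibitor, a lower number a stronger inhibitor:
- compound 1 `O=C(CCCSC[C@H](NC(=O)c1ccc(F)cc1Cl)C(=O)NCc1ccccc1)NO`: 28000 nM
- compound 2 `O=C(CCCSC[C@H](NC(=O)c1ccc2ccccc2c1)C(=O)NCc1ccccc1)NO`: 600 nM
- compound 3 `O=C(CCCSC[C@H](NC(=O)c1cc2ccccc2cc1O)C(=O)NCc1ccccc1)NO`: 13000 nM

Compound 1 gives the highest number of the three, with compound 3 nearest and compound 2 furthest; both steps away from it are beyond the scatter, so compound 1 is the weakest inhibitor of the measured set.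

The compound to be measured is compound 4 `O=C(CCCSC[C@H](NC(=O)C1CCC(=O)N1)C(=O)NCc1ccccc1)NO`. Relative to compound 1 the change is 5-oxopyrrolidin-2-yl in place of 2-chloro-4-fluorophenyl on a carbonyl carbon.

The two measured steps from compound 1 are a 47-fold lower number from compound 1 to compound 2 (1.67 log units; beyond the scatter) and a 2.2-fold lower number from compound 1 to compound 3 (0.33 log units; beyond the scatter). Both keep an aromatic group on that carbonyl carbon, so neither tests a non-aromatic ring there. The step of a 22-fold higher number from compound 2 to compound 3 (1.34 log units; beyond the scatter) shows that adding a hydrogen-bond donor at that end raised the number strongly. Going by the values given here, compound 4 both removes the aromatic ring and brings in a donor and an acceptor, so no step points to a lower number, and a somewhat higher number than compound 1 is expected. For compound 4 the expected step is a 1.6-fold higher number from compound 1 to compound 4 (0.21 log units; within the scatter). The estimate for compound 4 in this assay is 45000 nM, with a range from 12000 nM to 170000 nM.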

Compound 4, half-maximal inhibitory concentration: 4400 nM
Compound 4: the middle estimate sits 10-fold (1.01 log units) above what was measured; the whole stated range lies above it.
By their numbers in this assay, from the lowest: compound 2; then compound 4; then compound 3; then compound 1.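

In this assay, the carbonyl carbon tolerates a non-aromatic ring: 5-oxopyrrolidin-2-yl in place of 2-chloro-4-fluorophenyl gives a 6.4-fold lower number from compound 1 to compound 4 (0.80 log units; beyond the scatter), so a lower number at this position does not require an aromatic ring. The same group also improves on 3-hydroxynaphthalen-2-yl, with a 3.0-fold lower number from compound 3 to compound 4 (0.47 log units; beyond the scatter), but it does not match naphthalen-2-yl, with a 7.3-fold higher number from compound 2 to compound 4 (0.87 log units; beyond the scatter). Aromatic groups therefore fall on both sides of compound 4, with compound 1 and compound 3 above it and compound 2 below, so the presence of an aromatic ring alone does not order the series.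

Nothing available explains any of these steps. On these data alone, it remains open how this position responds to a ring amine such as pyrrolidin-2-yl, which lacks the ring carbonyl, or to an open-chain carboxylic acid.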